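Halogen in place of phenyl on the thiophene arm

This account rests on a few compounds, and the source may have more. Where it says the series, first, only, none or still open, it means among the compounds named here.

Compound 1 `C[C@H]1[C@H](NCc2ccsc2)C[C@H]2C[C@@H]1C2(C)C` gives 50000 nM in an ADME assay on MDCK cells (Canis lupus familiaris) for cytotoxicity, read by microscopy, with a stated time of 48 h; on this read-out higher numbers stand for lower toxicity in this test and lower numbers for higher toxicity in this test. Compound 2 `C[C@H]1[C@H](NCc2ccc(Cl)s2)C[C@H]2C[C@@H]1C2(C)C` gives 25000 nM, and compound 3 `C[C@H]1[C@H](NCc2sccc2-c2ccccc2)C[C@H]2C[C@@H]1C2(C)C` gives 12500 nM, the lowest of the three numbers: compound 2 lies within the scatter of it, compound 1 beyond it. Within the data shown here, the one step between neighbours is a 2.0-fold lower number from compound 1 to compound 2 (0.30 log units; within the scatter). Compound 4 `C[C@H]1[C@H](NCc2sccc2Br)C[C@H]2C[C@@H]1C2(C)C` carries bromo in place of phenyl on an aromatic carbon. Among the measured compounds shown here, only that step bears on the change, since it also puts a halogen on the five-membered aromatic ring with 1 sulfur, and compound 2 with its chloro group stands at 25000 nM. A step back toward that number is expected, a 2.0-fold higher number from compound 3 to compound 4 (0.30 log units; within the scatter). Compound 4 is therefore estimated at 25000 nM, with a range from 12500 nM to 50000 nM.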

Compound 4, minimum cytotoxic concentration: 50000 nM
Estimate against measurement, compound 4: 2.0-fold (0.30 log units) below; measured number inside the range.
By their numbers in this assay, from the lowest: compounds 3, 2, 1 and 4 (each within the scatter of the next, the first and the last beyond it).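

Among these compounds, on the aromatic carbon two ring bonds from the ring sulfur, bromo in place of phenyl gives a 4.0-fold higher number from compound 3 to compound 4 (0.60 log units; beyond the scatter) in this assay, the only step here beyond the scatter. The bromo compound does not separate from the other two thiophene arms: a 2.0-fold higher number from compound 2 to compound 4 (0.30 log units; within the scatter) and no change at the digits printed from compound 1 to compound 4 (within the scatter) both stay within the scatter. No measurement here bears on the reason for the step with phenyl.

Open, going by these compounds, is whether a methyl, a methoxy group or a pyridyl ring on this aromatic carbon would stand with compound 4 or with compound 3.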